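Cyano for Bromo on the Sulfonyl Ring: Expected Cytotoxicity

The source may hold more compounds than are shown below. What is called first, only, known or untested is meant among the compounds shown, and "the series" means these compounds.

Measured so far:
- compound 1, `O=C1/C(=C/c2ccncc2)CN(S(=O)(=O)c2ccc(Br)cc2)C/C1=C\c1ccccc1F`: 9300 nM
- compound 2, `N#Cc1ccc(S(=O)(=O)N2C/C(=C\c3ccncc3)C(=O)/C(=C/c3ccccc3F)C2)cc1`: 4500 nM
- compound 3, `O=C1/C(=C/c2cccnc2)CN(S(=O)(=O)c2ccc(Br)cc2)C/C1=C\c1ccccc1C(F)(F)F`: 2730 nM

All three were tested in a functional assay on HepG2 cells (Homo sapiens) for cytotoxicity, read by MTT assay, with a stated time of 24 h; on this read-out higher numbers stand for weaker inhibition and lower numbers for stronger inhibition. Compound 1 and compound 2 share one core and differ in a single spot: cyano in place of bromo on an aromatic carbon. That swap gave a 2.1-fold lower number from compound 1 to compound 2 (0.32 log units; beyond the scatter), a step that is small but beyond the usual scatter of this assay.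

Compound 3 rests on a different core. How that core differs from the core of compound 1 is not broken down here. In this assay compound 3 gives the lowest of the three numbers; against compound 2 the gap lies within the scatter, so no order between them can be claimed, while against compound 1 the gap lies beyond it.

Compound 4, `N#Cc1ccc(S(=O)(=O)N2C/C(=C\c3cccnc3)C(=O)/C(=C/c3ccccc3C(F)(F)F)C2)cc1`, has not yet been measured. It differs from compound 3 exactly as compound 2 differs from compound 1: cyano in place of bromo on an aromatic carbon. The place of the change is described in the same words in both pairs, so it is the same change carried onto the second core. Within the data shown here, because the earlier pair showed a 2.1-fold lower number from compound 1 to compound 2 (0.32 log units; beyond the scatter), a step of similar size is expected here, though with only one prior example the direction is far from certain. The expected step is a 2.1-fold lower number from compound 3 to compound 4 (0.32 log units; beyond the scatter). For compound 4 in this assay the estimate is 1300 nM, with a likely range from 500 nM to 3500 nM.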

Compound 4, half-maximal inhibitory concentration: 5060 nM
For compound 4 the middle estimate is 3.9-fold (0.59 log units) below the measured one, outside the stated range (above it).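

In this assay, cyano in place of bromo on the core of compound 3 gives a 1.9-fold higher number from compound 3 to compound 4 (0.27 log units; within the scatter), a step too small to place any order on this pair, so this core shows no clear effect of the swap. The gain seen on the core of compound 1 therefore does not carry over as a fixed step, and the two steps differ by more than repeat measurements would explain: the same change on two cores in this assay, a 2.1-fold lower number (0.32 log units; beyond the scatter) from compound 1 to compound 2 and a 1.9-fold higher number (0.27 log units; within the scatter) from compound 3 to compound 4, 3.8-fold (0.58 log units) apart, beyond the scatter of two such steps

This shows that, in this series, the result of the swap depends on the core that carries it, but it does not show which part of the core is responsible, since the two cores are not broken down into single changes, and two pairs are too few to support a rule for any other core.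

Still open, on these data alone, is how cyano in place of bromo would behave on a core that differs from the core of compound 1 in only one place, which would help show where the dependence arises. Also open, as far as these compounds go, is how other groups in that same place on the sulfonyl-bearing ring, such as an amine, a carboxylic acid or a methoxy group, would compare with bromo and cyano on each core.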